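A Shift of the Alkyl Group on the Aryl Urea

The source may report more compounds than this note shows. Statements on the series, on what has been measured and on what is new or still open speak of the compounds shown alone.

Measured so far:
compound 1, `Cc1cccc(NC(=O)Nc2cccc(CNc3nccnc3Cl)c2)c1`: 11200 nM
compound 2, `O=C(Nc1cccc(CNc2nccnc2Cl)c1)Nc1ccc(Cl)cc1Cl`: 7230 nM

Both numbers come from a functional assay on HepG2 cells (Homo sapiens) for antiproliferative activity, read by MTT assay, with a stated time of 48 h; a lower number here means a stronger inhibitor, a higher number a weaker inhibitor. Compound 1 carries the highest of the two numbers; its nearest neighbour is compound 2, and the step of a 1.5-fold lower number from compound 1 to compound 2 (0.19 log units; within the scatter) lies within the scatter, so the two compounds cannot be told apart on these data.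

Compound 3, `CCc1ccccc1NC(=O)Nc1cccc(CNc2nccnc2Cl)c1`, has not yet been measured in this assay. It differs from compound 1 in one place: 2-ethylphenyl in place of 3-methylphenyl on an amide-type nitrogen. Among the compounds with values here, the only measured step, a 1.5-fold lower number from compound 1 to compound 2 (0.19 log units; within the scatter), also concerns an exchange on that same amide-type nitrogen, and it stayed within the scatter even though the group changed rather more than it does here. There is therefore no basis in the measured compounds for expecting a step beyond the scatter in this assay in either direction.

Compound 3 is accordingly expected to give about 10000 nM in this assay, with a plausible range from 4000 nM to 25000 nM. The expected step is a 1.1-fold lower number from compound 1 to compound 3 (0.05 log units; within the scatter).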

Compound 3, half-maximal inhibitory concentration: 7860 nM
Compound 3: middle estimate off by 1.3-fold (0.10 log units), on the high side, and the stated range covers the measured number.
By their numbers in this assay, from the lowest: compounds 2, 3 and 1 (each within the scatter of the next).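

In this assay, the exchange of 3-methylphenyl for 2-ethylphenyl on the amide-type nitrogen gives a 1.4-fold lower number from compound 1 to compound 3 (0.15 log units; within the scatter), and the exchange of 2,4-dichlorophenyl for 2-ethylphenyl on that same nitrogen gives a 1.1-fold higher number from compound 2 to compound 3 (0.04 log units; within the scatter). The earlier pair offered a single exchange at this position, whereas three different substituted phenyl groups can now be compared, and none can be told apart from the others in this assay, even though the change from compound 1 to compound 3 alters both the alkyl group and its place on the ring. No other measurement is available to explain why these compounds cannot be separated.

The compounds shown leave open whether a 2-methylphenyl group would also fall within the scatter of these three, which would help separate the effect of the longer alkyl group from that of its place on the ring. They also leave open whether a carboxylic acid or an amine on this phenyl ring, or a longer chain such as butyl, would produce a step beyond the scatter.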